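The source may report more compounds than this note shows. Statements on the series, on what has been measured and on what is new or still open speak of the compounds shown alone.

Compound 3 `Cn1cncc1CN1CC(N(CC2CCN(C(=O)Nc3ccc(Br)cc3)CC2)S(=O)(=O)c2ccccn2)Cc2cc(C#N)ccc21` stands at the top of the three numbers measured in an ADME assay on Caco-2 cells (Homo sapiens) for permeability, in the apical to basolateral direction (on this read-out higher numbers stand for higher permeability and lower numbers for lower permeability), giving 0.6 10^-6 cm/s. Its nearest neighbour is compound 1 `Cn1cncc1CN1CC(N(CC2CCN(C(=O)CNC(=O)OC(C)(C)C)CC2)S(=O)(=O)c2ccccn2)Cc2cc(C#N)ccc21`, which in this assay gives 0.5 10^-6 cm/s, a gap within the scatter. The furthest is compound 2 `Cn1cncc1CN1CC(N(CC2CCN(S(C)(=O)=O)CC2)S(=O)(=O)c2ccccn2)Cc2cc(C#N)ccc21`, which in this assay gives 0.1 10^-6 cm/s.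

Compound 4 `Cn1cnc(S(=O)(=O)N2CCC(CN(C3Cc4cc(C#N)ccc4N(Cc4cncn4C)C3)S(=O)(=O)c3ccccn3)CC2)c1` differs from compound 3 at the amine nitrogen in a ring ((1-methyl-1H-imidazol-4-yl)sulfonyl in place of (4-bromophenyl)carbamoyl on an amine nitrogen in a ring). Within the data shown here, two measured steps bear on this position. There was a 5.0-fold lower number from compound 1 to compound 2 (0.70 log units; beyond the scatter), and there was a 6.0-fold higher number from compound 2 to compound 3 (0.78 log units; beyond the scatter). Both steps show that placing a methylsulfonyl group on this ring nitrogen in compound 2 went with the lowest number of the three, while the carbamate-bearing acyl group of compound 1 and the (4-bromophenyl)carbamoyl group of compound 3 gave numbers within the scatter of each other. Compound 4 carries a (1-methyl-1H-imidazol-4-yl)sulfonyl group at this nitrogen, so it shares the sulfonyl attachment of compound 2.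

In this assay compound 4 is therefore expected to fall below compound 3, with an estimated step of a 2.4-fold lower number from compound 3 to compound 4 (0.38 log units; beyond the scatter), because compound 2 gave 0.1 10^-6 cm/s with a sulfonyl on the same nitrogen. The estimate for compound 4 in this assay is 0.25 10^-6 cm/s, with a range from 0.08 10^-6 cm/s to 0.6 10^-6 cm/s.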

Compound 4, apparent permeability: 0.1 10^-6 cm/s
The estimate for compound 4 lay 2.5-fold (0.40 log units) above the measured number; the range from low to high includes it.
By their numbers in this assay, from the lowest: compounds 2 and 4 (each within the scatter of the next); then compounds 1 and 3 (each within the scatter of the next).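

In this assay the swap on the sulfonyl sulfur, 1-methyl-1H-imidazol-4-yl in place of methyl, gave no change at the digits printed from compound 2 to compound 4 (within the scatter), so a second and much larger sulfonyl group sits with the methylsulfonyl group rather than with the carbonyl-linked groups. The low number of compound 2 is therefore no longer a single case: compound 4 stands apart from the carbonyl-linked groups too, with a 6.0-fold lower number from compound 3 to compound 4 (0.78 log units; beyond the scatter) and a 5.0-fold lower number from compound 1 to compound 4 (0.70 log units; beyond the scatter). Among these four compounds, the link on the amine nitrogen in a ring divides the numbers into a sulfonyl pair and a carbonyl pair, no compound goes against this division, and nothing presented here explains it.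

The compounds shown leave open where a plain acetyl group, a dimethylaminosulfonyl group or the free ring amine would fall relative to these two pairs. They also leave open whether the same division holds when the shared core is changed elsewhere, for instance when the nitrile is replaced by a carboxylic acid.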